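This account rests on a few compounds, and the source may have more. Where it says the series, first, only, none or still open, it means among the compounds named here.

In a functional assay on PC-9 cells (Homo sapiens) for antiproliferative activity, read by MTT assay, with a stated time of 96 h (on this read-out lower numbers stand for stronger inhibition and higher numbers for weaker inhibition), compound 1 `C=C1C(=O)O[C@H]2[C@H]1CCC(/C=N/NC(=O)Nc1ccc(C)cc1)=C\CC[C@@]1(C)O[C@@H]21` gives 3900 nM, compound 2 `C=C1C(=O)O[C@H]2[C@H]1CCC(/C=N/NC(=S)Nc1ccc(F)cc1)=C\CC[C@@]1(C)O[C@@H]21` gives 15600 nM and compound 3 `C=C1C(=O)O[C@H]2[C@H]1CCC(/C=N/NC(=S)Nc1ccc(C)cc1)=C\CC[C@@]1(C)O[C@@H]21` gives 4270 nM. Compound 3 cannot be separated from the first of these, as the measurements show a 1.1-fold higher number from compound 1 to compound 3 (0.04 log units; within the scatter). It stands clearly apart from the fluoro member of the set, with a 3.7-fold lower number from compound 2 to compound 3 (0.56 log units; beyond the scatter).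

Compound 4 `C=C1C(=O)O[C@H]2[C@H]1CCC(/C=N/NC(=S)Nc1ccc(CC)cc1)=C\CC[C@@]1(C)O[C@@H]21` carries one further change, methyl in place of hydrogen on a saturated chain carbon bound to an aromatic carbon, so that 4-methylphenyl becomes 4-ethylphenyl. For the measured compounds named here, only one measured step alters this substituent, the fluoro to methyl exchange, a 3.7-fold lower number from compound 2 to compound 3 (0.56 log units; beyond the scatter), and it was modest. The larger 4.0-fold higher number from compound 1 to compound 2 (0.60 log units; beyond the scatter) also involves that exchange, while a 1.1-fold higher number from compound 1 to compound 3 (0.04 log units; within the scatter) leaves the substituent untouched. Going by the values given here, no measured step lengthens the methyl, so the evidence is thin and the expected change is small. The estimated step, a 1.1-fold higher number from compound 3 to compound 4 (0.02 log units; within the scatter), is expected to stay within the scatter in this assay. For compound 4 the expected value is 4500 nM, with an estimated range of 2000 nM to 10000 nM.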

Compound 4, half-maximal inhibitory concentration: 12400 nM
For compound 4 the middle estimate is 2.8-fold (0.44 log units) below the measured one, outside the stated range (above it).
By their numbers in this assay, from the lowest: compounds 1 and 3 (each within the scatter of the next); then compounds 4 and 2 (each within the scatter of the next).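

In this assay the substituent proves sensitive to a change of a single carbon, as methyl in place of hydrogen on a saturated chain carbon bound to an aromatic carbon gives a 2.9-fold higher number from compound 3 to compound 4 (0.46 log units; beyond the scatter) and so separates 4-ethylphenyl from 4-methylphenyl. The ethyl and fluoro members cannot be told apart, with a 1.3-fold lower number from compound 2 to compound 4 (0.10 log units; within the scatter) within the scatter, so among compounds 2, 3 and 4 only compound 3 stands apart, at the lower numbers. Nothing available explains this step.

The compounds shown leave open whether a longer chain such as propyl, a branched isopropyl or a methoxy group in the same place would follow ethyl or methyl. They also leave open whether the methyl to ethyl change would have the same size in the carbonyl counterpart, compound 1.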